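Series notes: methoxy added to the pyridin-2-yl arm

The source may hold more compounds than are shown below. What is called first, only, known or untested is meant among the compounds shown, and "the series" means these compounds.

Three compounds of the shared core have numbers in a functional assay on HEK293 cells for positive allosteric modulation of metabotropic glutamate receptor 5 (Homo sapiens), read by calcium flux; on this read-out higher numbers stand for larger maximal responses and lower numbers for smaller maximal responses. Compound 1 `O=C1c2cc(COc3ccccc3)nn2CCN1c1ccc(F)cc1` gives 79% in this assay. Compound 2 `COc1ccc(N2CCn3nc(COc4ccccc4)cc3C2=O)cc1` gives 58%. Compound 3 `O=C1c2cc(COc3ccccc3)nn2CCN1c1ccccn1` gives 69%. Compound 3 stands second highest of the three; its nearest neighbour is compound 1, with a number 10 percentage points lower from compound 1 to compound 3 (within the scatter), and its furthest is compound 2, with a number 11 percentage points higher from compound 2 to compound 3 (beyond the scatter).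

Compound 4 `COc1ccc(N2CCn3nc(COc4ccccc4)cc3C2=O)nc1` differs from compound 3 in one place: methoxy in place of hydrogen on an aromatic carbon.

Among the measured compounds shown here, the one measured step that bears on this change is the replacement of fluoro by methoxy on an aromatic carbon, a number 21 percentage points lower from compound 1 to compound 2 (beyond the scatter). For the measured compounds named here, the comparison is loose: there the methoxy replaced fluoro on 4-fluorophenyl, here it replaces hydrogen on pyridin-2-yl, and no measured pair shows a substituted pyridin-2-yl at all. The two swaps on the amide-type nitrogen in a ring, 1>3 within scatter and 2>3 modest, suggest this position tolerates change without large effects. A modest decrease in this assay is therefore expected, likely smaller than the measured methoxy step. The expected change is a number 11 percentage points lower from compound 3 to compound 4 (beyond the scatter). Compound 4 is estimated at 58%, with a range from 42% to 74%.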

Compound 4, largest response reached (Emax), in percent of the reference or control that the assay uses: 74%
Compound 4: the middle estimate sits 16 percentage points below what was measured; the range from low to high includes it.
By their numbers in this assay, from the lowest: compound 2; then compounds 3, 4 and 1 (each within the scatter of the next).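

On the pyridin-2-yl arm, methoxy on the ring carbon two atoms from the ring nitrogen does not move the read-out in this assay beyond the scatter, a number 5 percentage points higher from compound 3 to compound 4 (within the scatter), so the drop seen on the phenyl arm, a number 21 percentage points lower from compound 1 to compound 2 (beyond the scatter), does not recur with this change, although that step replaced fluoro rather than hydrogen. Among the compounds shown here, with methoxy present on both arms, the ring itself makes a difference, a number 16 percentage points higher from compound 2 to compound 4 (beyond the scatter), which is the first comparison showing that a methoxy-bearing arm can differ with the ring that carries it. The 5-methoxypyridin-2-yl arm also stays within the scatter of the 4-fluorophenyl arm, a number 5 percentage points lower from compound 1 to compound 4 (within the scatter), so this substituted pyridine is compatible with a maximal response in the range of the best number in the set.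

No measurement at hand accounts for any of these steps. Still open, from the compounds shown here alone, is whether an ethoxy group, an amine or a carboxylic acid at this ring carbon would stay as close to compound 3 as methoxy does, and whether methoxy on another carbon of the pyridin-2-yl ring would do the same.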